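The source may hold more compounds than are shown below. What is called first, only, known or untested is meant among the compounds shown, and "the series" means these compounds.

Measured so far, in a functional assay (aorta) with Oryctolagus cuniculus as the target; a lower number here means tighter binding, a higher number weaker binding:
compound 1 `COc1cc(C(C)=O)ccc1OCCCN1CCC(C(c2ccc(F)cc2F)c2ccc(F)cc2F)CC1` — 15.9 nM
compound 2 `COc1cc(C(C)=O)ccc1OCCCCN1CCC(C(c2ccc(F)cc2)c2ccc(F)cc2)CC1` — 2.51 nM
compound 3 `COc1cc(C(C)O)ccc1OCCCN1CCC(C(c2ccc(F)cc2)c2ccc(F)cc2)CC1` — 10 nM

Compound 3 stands second highest of the three numbers. Its nearest neighbour is compound 1, whose value lies within the usual scatter of it, so no order between those two can be read; compound 2 gives a lower number, and that gap lies beyond the scatter.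

Compound 4 `Fc1ccc(C(c2ccc(F)cc2)C2CCN(CCCSc3ccccc3)CC2)cc1` has not yet been measured. It differs from compound 3 in one place: phenylsulfanyl in place of 4-(1-hydroxyethyl)-2-methoxyphenoxy on a saturated chain carbon, three bonds along the chain from an amine nitrogen in a ring. Within the data shown here, no measured pair shows a change of this kind, so the size of the step rests on the structural change alone. He expects the step in this assay to run upward, toward weaker binding, by a modest amount beyond the scatter, since the group that leaves carries the only hydrogen-bond donor and most of the acceptors among the three measured compounds, and compound 4 is expected to move by a 3.0-fold higher number from compound 3 to compound 4 (0.48 log units; beyond the scatter). For compound 4 he estimates 30 nM, within a range from 8 nM to 120 nM.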

Compound 4, dissociation constant: 3.16 nM
Compound 4: the middle estimate sits 9.5-fold (0.98 log units) above what was measured; the whole stated range lies above it.
By their numbers in this assay, from the lowest: compounds 2 and 4 (each within the scatter of the next); then compounds 3 and 1 (each within the scatter of the next).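

In this assay, phenylsulfanyl in place of 4-(1-hydroxyethyl)-2-methoxyphenoxy gives a 3.2-fold lower number from compound 3 to compound 4 (0.50 log units; beyond the scatter). This is the first single change shown at this chain position, and it indicates that the larger group, with its hydrogen-bond donor, is not required here for a low number. Nothing at hand accounts for the direction of this step. The compounds shown leave open whether the step comes from the sulfur or from the loss of the methoxy and 1-hydroxyethyl groups, which a plain phenoxy group would separate. Going by these compounds, how a longer chain would behave with phenylsulfanyl also remains open.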